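Chloro in place of hydrogen on compound 3

This account rests on a few compounds, and the source may have more. Where it says the series, first, only, none or still open, it means among the compounds named here.

In an ADME assay on Vero 76 cells (Chlorocebus sabaeus) for cytotoxicity, read by MTT assay, with a stated time of 96 h (on this read-out lower numbers stand for higher toxicity in this test and higher numbers for lower toxicity in this test), compound 3 (`Cc1ccc(-c2nn(-c3ccccc3)cc2CNc2ccccc2)cc1`) gives 52000 nM and stands within the scatter of compound 2 (`Cc1ccc(-c2nn(-c3ccccc3)cc2CNc2ccc(Br)cc2)cc1`) at 92000 nM in the same test. In this assay compound 1 (`Cc1ccc(NCc2cn(-c3ccccc3)nc2-c2ccc(C)cc2)cc1`) gives > 100000 nM as a limit of the assay, not a number. Compound 4 (`Cc1ccc(-c2nn(-c3ccccc3)cc2CNc2ccc(Cl)cc2)cc1`) differs from compound 3 by chloro in place of hydrogen on an aromatic carbon, para to a large group (chloro in place of hydrogen on an aromatic carbon). The closest measured changes are a 1.8-fold lower number from compound 2 to compound 3 (0.25 log units; within the scatter) for hydrogen in place of bromo and an at least 1.9-fold lower number from compound 1 to compound 3 (0.28 log units; that floor lies within the scatter) for hydrogen in place of methyl. Read in reverse, the bromo step (a 1.8-fold lower number from compound 2 to compound 3 (0.25 log units; within the scatter)) points to a somewhat higher number, but no change beyond the scatter is expected in this assay. The expected step is a 1.4-fold higher number from compound 3 to compound 4 (0.14 log units; within the scatter) and no more. For compound 4 the estimated value is 72000 nM with an expected range of 40000 nM to 100000 nM in this test.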

Compound 4, half-maximal cytotoxic concentration: > 100000 nM
Compound 4: only a limit was reported (the forecaster's own chance of this, stated with the estimate: 25%); at least 1.3-fold (0.14 log units) between middle value and limit.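

In this assay, chloro in place of hydrogen gives an at least 1.9-fold higher number from compound 3 to compound 4 (0.28 log units; that floor lies within the scatter), and chloro in place of bromo gives an at least 1.0-fold higher number from compound 2 to compound 4 (0.03 log units; that floor lies within the scatter); both floors lie within the scatter, so chloro at this position is not yet separated from hydrogen or bromo. Compound 4 gives > 100000 nM, a limit of the assay and not a number. The step between compound 1 and compound 4 cannot be read because both values are limits: the limit of > 100000 nM in this assay, at which 2 of the 4 values shown sit.

On these data alone, what an amine or a carboxylic acid at this position would give remains open, as does the actual number for compound 4.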